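Taking the cyano group off compound 3

A few compounds are considered here, and "the series" means these few. Any claim that something is new, unique, unknown or untested is made for them only; others in the source may bear on it.

In an ADME assay on the whole organism (Rattus norvegicus) for pharmacokinetics, at a dose of 0.5 mg/kg by the intravenous route (on this read-out higher numbers stand for fast clearance and lower numbers for slow clearance), compound 1 `CC1CN(c2cnc3c(C(F)(F)F)nn(C(C)c4ccc(Cl)cc4Cl)c3n2)CCC1N1CCCCC1`, which carries trifluoromethyl, gives 56.7 mL/min/kg. With methyl at that carbon, compound 2 `Cc1nn(C(C)c2ccc(Cl)cc2Cl)c2nc(N3CCC(N4CCCCC4)C(C)C3)cnc12` gives 38.3 mL/min/kg, and this change is a 1.5-fold lower number from compound 1 to compound 2 (0.17 log units; within the scatter). With cyano there, compound 3 `CC1CN(c2cnc3c(C#N)nn(C(C)c4ccc(Cl)cc4Cl)c3n2)CCC1N1CCCCC1` gives 102 mL/min/kg. Cyano in place of methyl is a 2.7-fold higher number from compound 2 to compound 3 (0.43 log units; beyond the scatter), while cyano in place of trifluoromethyl is a 1.8-fold higher number from compound 1 to compound 3 (0.26 log units; within the scatter). Compound 3 therefore stands apart from only one of the other two measured compounds.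

Compound 4 `CC1CN(c2cnc3cnn(C(C)c4ccc(Cl)cc4Cl)c3n2)CCC1N1CCCCC1` differs from compound 3 by hydrogen in place of cyano on an aromatic carbon. Going by the values given here, no measured compound has hydrogen at this carbon, so the data offer no direct precedent. The nearest guide is the pair of steps that bring cyano in, since compound 4 takes it out again. The step without cyano, a 1.5-fold lower number from compound 1 to compound 2 (0.17 log units; within the scatter), suggests that the number may not depend strongly on which non-cyano group is present. A lower number is therefore expected, of about the size of those two steps, and the expected change is a 1.7-fold lower number from compound 3 to compound 4 (0.23 log units; within the scatter). For compound 4 the estimated clearance is 60 mL/min/kg, with an expected range from 32 mL/min/kg to 110 mL/min/kg.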

Compound 4, clearance: 122 mL/min/kg
Estimate against measurement, compound 4: 2.0-fold (0.31 log units) below; the measured number lies above the stated range.
By their numbers in this assay, from the lowest: compounds 2, 1, 3 and 4 (each within the scatter of the next, the first and the last beyond it).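

In this assay, the compound with hydrogen at this carbon does not separate from the one with cyano (a 1.2-fold higher number from compound 3 to compound 4 (0.08 log units; within the scatter)), so a number at the high end of this series is not a mark of cyano alone. Hydrogen does stand apart from methyl (a 3.2-fold higher number from compound 2 to compound 4 (0.50 log units; beyond the scatter)) and from trifluoromethyl (a 2.2-fold higher number from compound 1 to compound 4 (0.33 log units; beyond the scatter)), which makes these two groups the ones that sit with lower numbers than hydrogen here, while compound 3 goes against any rule that simply putting a group on this carbon lowers the number. Nothing shown here explains why cyano parts company with the other two groups.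

The compounds shown leave open whether an ethyl group, a methoxy group or an amine at this carbon would fall with methyl and trifluoromethyl or with hydrogen and cyano. They also leave open whether the same grouping would hold if the 1-(2,4-dichlorophenyl)ethyl group were replaced by another substituent on the shared core.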